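Acyl group change on the shared core of compound 1

The source may report more compounds than this note shows. Statements on the series, on what has been measured and on what is new or still open speak of the compounds shown alone.

Measured so far:
compound 1 `Cc1ccc(C(=O)N[C@@H](C(=O)N2CCC(c3ccc(Cl)cc3)CC2)C(C)C)cc1`, 25 nM
compound 2 `O=C(N[C@@H](C(=O)N1CCC(c2ccc(Cl)cc2)CC1)C1CCCCC1)c1ccccc1`, 121 nM
compound 3 `CC[C@@H](NC(=O)CC(C)C)C(=O)N1CCC(c2ccc(Cl)cc2)CC1`, 152 nM

In an assay on THP-1 cells for displacement of a labelled ligand from C-C chemokine receptor type 1 (Homo sapiens) (a higher number here means a weaker inhibitor, a lower number a stronger inhibitor), compound 1 gives 25 nM, the lowest of the three numbers. Compound 2 gives 121 nM and compound 3 gives 152 nM; both gaps to compound 1 lie beyond the scatter, so compound 1 is the strongest inhibitor among the three on the numbers shown. Compound 2 and compound 3 differ from compound 1 in more than one place, so no single change has been isolated between measured compounds.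

Compound 4 `Cc1cccc(CCC(=O)N[C@@H](C(=O)N2CCC(c3ccc(Cl)cc3)CC2)C(C)C)c1` is not yet measured. It differs from compound 1 as follows: 2-(3-methylphenyl)ethyl in place of 4-methylphenyl on a carbonyl carbon. The acyl group on that carbonyl carbon is therefore changed while the rest of the shared core is kept. Among the measured compounds, compound 3 carries a non-aromatic acyl group on the same carbonyl and gives 152 nM, but its other difference from compound 1 prevents any reading of this as a step.

Expectation: a weakening step from compound 1 to compound 4 of a 2.8-fold higher number from compound 1 to compound 4 (0.45 log units; beyond the scatter), probably beyond the scatter but uncertain in size. Compound 4 is estimated at 70 nM, with a range from 25 nM to 200 nM.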

Compound 4, half-maximal inhibitory concentration: 22 nM
Compound 4: the middle estimate sits 3.2-fold (0.50 log units) above what was measured; measured number outside the range, below it.
By their numbers in this assay, from the lowest: compounds 4 and 1 (each within the scatter of the next); then compounds 2 and 3 (each within the scatter of the next).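

In this assay, for the compounds shown here, the only single change isolated so far, 2-(3-methylphenyl)ethyl in place of 4-methylphenyl on the carbonyl carbon, gives a 1.1-fold lower number from compound 1 to compound 4 (0.06 log units; within the scatter) and so leaves the number where it was. The position therefore accepts a larger acyl substituent, 9 heavy atoms against 7, with one six-membered aromatic ring of carbon only kept on both sides and the low number of compound 1 retained in compound 4. Nothing measured here explains why the number holds across this change.

The single step moves the aromatic ring away from the carbonyl carbon through the ethyl chain and also changes the methyl from the 4-methylphenyl to the 3-methylphenyl pattern, so the compounds shown cannot assign the outcome to either feature alone. From the compounds shown here alone, how far this acceptance extends stays open, whether to a longer chain on the carbonyl carbon or to an amine or a carboxylic acid on the aromatic ring in place of the methyl.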